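The compounds below may be only part of what the source reports. "The series", "measured", "known", "first", "only" and "open" are said of these compounds alone.

In a functional assay on K562 cells (Homo sapiens) for inhibition, read by MTT assay, with a stated time of 24 h (a higher number here means a weaker inhibitor, a lower number a stronger inhibitor), compound 1 `CCOC1c2cc(OCc3cc(C)cc(C)c3)c(OCc3cc(C)cc(C)c3)cc2CCN1C(=O)OC(C)(C)C` stands at > 20000 nM, which is a limit of the assay and not a number. Compound 2 `CCC[C@@H]1C[C@@H](O)/C=C\C(CC)[C@H]2c3cc(OCc4ccccc4)c(OCc4ccccc4)cc3CCN12` gives a true number, 5610 nM. Compound 3 `C/C=C/C(=O)CC1c2cc(OCc3cc(C)cc(C)c3)c(OCc3cc(C)cc(C)c3)cc2CCN1C(=O)OC(C)(C)C` keeps the core of compound 1 but carries ((prop-1-en-1-yl)carbonyl)methyl in place of ethoxy on a saturated ring carbon. Within the data shown here, no measured pair shows what such a swap does, so only a small change towards stronger inhibition is expected, an estimated at least 1.6-fold lower number from compound 1 to compound 3 (0.22 log units; that floor lies within the scatter). A result at the same limit would be no surprise. The expected value for compound 3 is 12000 nM, within a range from 4000 nM to 30000 nM.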

Compound 3, half-maximal inhibitory concentration: > 20000 nM
Compound 3 was reported as a limit (the forecaster's own chance of this, stated with the estimate: 50%); middle value at least 1.6-fold (0.22 log units) from the limit.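

Compound 1 and compound 3 both stand at a limit and not at a number, so no step can be read between them: the limit of > 20000 nM in this assay, at which 2 of the 3 values shown sit.

On these data alone, whether putting ((prop-1-en-1-yl)carbonyl)methyl in place of ethoxy changes inhibition at all stays open.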